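Swapping Pyridin-4-yl for 6-Methoxypyridin-3-yl

This account rests on a few compounds, and the source may have more. Where it says the series, first, only, none or still open, it means among the compounds named here.

In an ADME assay on microsomes from liver (Homo sapiens), read by LC-MS, using NADPH, with a stated time of 10 min, tested at 0.5 uM (a higher number here means that more of the compound is left, a lower number that less of the compound is left), compound 1 (`COc1ccccc1-c1cccc(-c2cc3nc(C)c([C@H](OC(C)(C)C)C(=O)O)c(-c4cc(F)c5c(c4C)CCCO5)n3n2)c1`) gives 99%, while compound 2 (`Cc1nc2cc(-c3cccc(-c4ccncc4)c3)nn2c(-c2cc(F)c3c(c2C)CCCO3)c1[C@H](OC(C)(C)C)C(=O)O`) gives 46%, the lower of the two numbers. Compound 3 (`COc1ccc(-c2cccc(-c3cc4nc(C)c([C@H](OC(C)(C)C)C(=O)O)c(-c5cc(F)c6c(c5C)CCCO6)n4n3)c2)cn1`) departs from compound 2 as follows: 6-methoxypyridin-3-yl in place of pyridin-4-yl on an aromatic carbon. Among the measured compounds shown here, only one measured step bears on this change: a number 53 percentage points lower from compound 1 to compound 2 (beyond the scatter), where pyridin-4-yl replaced 2-methoxyphenyl. Compound 3 regains a methoxy group, though on a pyridine ring, so a large rise that recovers most of that step is expected. The estimated step is a number 32 percentage points higher from compound 2 to compound 3 (beyond the scatter). For compound 3 the expected value is 78%, with an estimated range of 55% to 98%.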

Compound 3, percent of the compound remaining: 73%
For compound 3 the middle estimate is 5 percentage points above the measured one; low and high end bracket the measured number.
By their numbers in this assay, from the lowest: compound 2; then compound 3; then compound 1.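

In this assay, 6-methoxypyridin-3-yl in place of pyridin-4-yl gives a number 27 percentage points higher from compound 2 to compound 3 (beyond the scatter), so a pyridine ring at this position need not stay as low as compound 2. The recovery is only partial: 6-methoxypyridin-3-yl in place of 2-methoxyphenyl gives a number 26 percentage points lower from compound 1 to compound 3 (beyond the scatter). No measurement here explains either step.

The compounds shown leave open how much of this gap belongs to the ring nitrogen and how much to where the methoxy group sits. They also leave open how an amine or an ethoxy group on this ring would fare.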